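Halogen swap on the 4-chlorophenyl series: compound 3 to compound 4

The source may report more compounds than this note shows. Statements on the series, on what has been measured and on what is new or still open speak of the compounds shown alone.

Values measured so far in a functional assay on OVCAR-3 cells (Homo sapiens) for inhibition, read by sulforhodamine B assay, with a stated time of 48 h (on this read-out lower numbers stand for stronger inhibition of growth and higher numbers for weaker inhibition of growth), are these:
compound 1 `CC(C)(C)NCc1c(C(=O)O)nn(-c2ccccc2)c1-c1ccc(Br)cc1` gives > 585000 nM (a limit, not a number)
compound 2 `CC(C)(C)NCc1c(C(=O)O)nn(-c2ccc(Cl)cc2)c1-c1ccc(F)cc1` gives 116000 nM
compound 3 `CC(C)(C)NCc1c(C(=O)O)nn(-c2ccc(Cl)cc2)c1-c1ccc(Cl)cc1` gives 84900 nM

For the measured compounds named here, compound 3 at 84900 nM lies within the scatter of compound 2 and, together with it, supplies the only true numbers. Going by the values given here, compound 1 is a limit only and yields no step.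

The next compound is compound 4 `CC(C)(C)NCc1c(C(=O)O)nn(-c2ccc(Cl)cc2)c1-c1ccc(Br)cc1` and its difference from compound 3 is bromo in place of chloro on an aromatic carbon in a single place. This is bromo in place of chloro on an aromatic carbon, para to a large group, or 4-chlorophenyl to 4-bromophenyl.

Among the compounds with values here, one measured step bears on this change. The step of a 1.4-fold lower number from compound 2 to compound 3 (0.14 log units; within the scatter) is a swap of one halogen for another at the same place, and it stays within the scatter. A single small step is thin support, but it gives no reason to expect a large move. In this assay no step beyond the scatter is expected, in either direction. The estimated step is a 1.1-fold lower number from compound 3 to compound 4 (0.03 log units; within the scatter) and it is expected to stay inside the scatter. For compound 4 the estimated value is 80000 nM with an expected range of 42000 nM to 150000 nM around it.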

Compound 4, concentration for 50% growth inhibition: 513000 nM
Compound 4: the middle estimate sits 6.4-fold (0.81 log units) below what was measured, and the stated range ends below it.
By their numbers in this assay, from the lowest: compounds 3 and 2 (each within the scatter of the next); then compound 4. At a limit, above all of these: compound 1.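

In this assay the halogen at this place turns out not to be freely exchangeable: the step of a 6.0-fold higher number from compound 3 to compound 4 (0.78 log units; beyond the scatter) lies beyond the scatter towards weaker inhibition of growth, the step of a 4.4-fold higher number from compound 2 to compound 4 (0.65 log units; beyond the scatter) points the same way, and the earlier step of a 1.4-fold lower number from compound 2 to compound 3 (0.14 log units; within the scatter) stays within the scatter. Among these three compounds the read-out thus sets bromo apart from fluoro and chloro, a separation the earlier pair could not show. Compound 3 and compound 4 differ by the exchange of one heavy atom, with no change in ring, hydrogen-bond donors, hydrogen-bond acceptors or net charge. The number for compound 4 also lies close to the ceiling of what this read-out reports: the limit of > 585000 nM in this assay, at which 1 of the 4 values shown sits.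

Compound 1 gives > 585000 nM as a limit and not a number. On these data alone, the step of an at least 1.1-fold lower number from compound 1 to compound 4 (0.05 log units; that floor lies within the scatter) rests on that limit, so the effect of chloro in place of hydrogen stays open. As far as these compounds go, whether iodo, methyl or trifluoromethyl at this place would fall with bromo or with fluoro and chloro also remains open.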